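The source may hold more compounds than are shown below. What is called first, only, known or untested is meant among the compounds shown, and "the series" means these compounds.

Measured so far:
- compound 1 `COc1ccc(Cn2c(N)nc3cc(Cl)c(Cl)cc32)cc1` gives 27000 nM
- compound 2 `Nc1nc2cc(Cl)c(Cl)cc2n1Cc1ccc(Cl)c(Cl)c1` gives 30000 nM

Both numbers come from a functional assay on CEM-SS cells (Homo sapiens) for cytotoxicity; a higher number here means a weaker inhibitor, a lower number a stronger inhibitor. Within the data shown here, compound 1 stands level with compound 2, the only other measured compound, and the two values lie within the scatter of each other.

Next in line is compound 3 `Nc1nc2cc(Cl)c(Cl)cc2n1Cc1ccc([N+](=O)[O-])cc1`, not yet measured in this assay. Relative to compound 1 it carries nitro in place of methoxy on an aromatic carbon, para to a large group: nitro in place of methoxy on an aromatic carbon.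

Among the measured compounds shown here, no measured pair differs in one place only, so the data give no direct size for this change. For the measured compounds named here, the only guide is that compound 1 at 27000 nM and compound 2 at 30000 nM do not separate, although their structures differ. On that thin basis, no step beyond the scatter is expected. The expected step is a 1.1-fold lower number from compound 1 to compound 3 (0.03 log units; within the scatter). For compound 3 the estimated value is 25000 nM, with an expected range of 10000 nM to 60000 nM.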

Compound 3, half-maximal inhibitory concentration: 32000 nM
The estimate for compound 3 lay 1.3-fold (0.11 log units) below the measured number; the measured number falls inside the stated range.
By their numbers in this assay, from the lowest: compounds 1, 2 and 3 (each within the scatter of the next).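

In this assay, nitro in place of methoxy on an aromatic carbon, para to a large group, gives a 1.2-fold higher number from compound 1 to compound 3 (0.07 log units; within the scatter). Among these compounds, the earlier compounds offered no pair differing in one place, so this is the first direct reading of a change at this position, and here the exchange of these two groups does not separate the compounds. No measured property bears on this result, and the data assign it no cause.

This single pair cannot show whether the same position would stay equally unresponsive with an amine, a carboxylic acid or a longer alkoxy chain in place of methoxy or nitro. It also leaves open whether changes to the shared core, such as replacing the two chlorines with hydrogen, or to the primary amine would produce a step beyond the scatter.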